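Sulfonyl aryl group in the piperidinyl-piperidine sulfonamide series

A few compounds are considered here, and "the series" means these few. Any claim that something is new, unique, unknown or untested is made for them only; others in the source may bear on it.

Measured so far in a functional assay on DLD-1 cells (Homo sapiens) for antiproliferative activity, read by CellTiter-Glo, with a stated time of 72 h; on this read-out lower numbers stand for stronger inhibition and higher numbers for weaker inhibition:
compound 1 `CC1CCN(C2CCN(S(=O)(=O)c3cn(C)cn3)CC2)CC1`: > 5000 nM
compound 2 `CC1CCN(C2CCN(S(=O)(=O)c3cccc(-c4ccc(F)cc4)c3)CC2)CC1`: 12 nM
compound 3 `CC1CCN(C2CCN(S(=O)(=O)c3cccc(-c4ccc(Cl)cc4)c3)CC2)CC1`: 15 nM

The value of compound 1 is a limit of this assay, not a number, and compound 1 therefore stands only at the weak end of the numbers shown (the limit of > 5000 nM in this assay, at which 1 of the 3 values shown sits). Among the measured compounds shown here, compound 2 and compound 3 carry a different group on the sulfonyl sulfur and both give low numbers; the one measured step, a 1.3-fold higher number from compound 2 to compound 3 (0.10 log units; within the scatter), concerns the chloro and fluoro substituent only and does not touch the group attached to the sulfonyl sulfur. For the measured compounds named here, no measured step therefore bears directly on the change to compound 4 `CC1CCN(C2CCN(S(=O)(=O)c3cccnc3)CC2)CC1`, which is pyridin-3-yl in place of 1-methyl-1H-imidazol-4-yl on a sulfonyl sulfur. Both compound 1 and compound 4 carry a single small aromatic ring on the sulfonyl sulfur, and compound 4 is expected to remain near the weak end, most likely again at a limit. The step of a number no higher from compound 1 to compound 4 (the limit leaves the size open) is estimated as no clear change. Compound 4 is expected to give about 5000 nM, in the range 1000 nM to 20000 nM.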

Compound 4, half-maximal inhibitory concentration: 2400 nM
Beside the measured number, compound 4's estimate is 2.1-fold (0.32 log units) above it, within the range that was stated.
By their numbers in this assay, from the lowest: compounds 2 and 3 (each within the scatter of the next); then compound 4. At a limit, above all of these: compound 1.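

In this assay, compound 4 gives a measured number for a single small aromatic ring on a sulfonyl sulfur. Compound 1 holds only a limit of the assay, not a number, so the change can be sized from one side only: the limit of > 5000 nM in this assay, at which 1 of the 4 values shown sits.

Pyridin-3-yl in place of 1-methyl-1H-imidazol-4-yl on a sulfonyl sulfur gives an at least 2.0-fold lower number from compound 1 to compound 4 (0.31 log units; beyond the scatter), so this ring swap alone moves the read-out, though the full size of the step stays unknown, and the printed values still leave compound 4 far from compound 2 at 12 nM.

As far as these compounds go, what a plain phenyl ring on the sulfonyl sulfur would give remains open, which leaves the part played by the ring nitrogen of pyridin-3-yl unsettled. Also open, from the compounds shown here alone, is whether an amine or a methoxy group on that ring could move the number toward those of the two-ring compounds.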